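A few compounds are considered here, and "the series" means these few. Any claim that something is new, unique, unknown or untested is made for them only; others in the source may bear on it.

In an ADME assay on TZM cells (Homo sapiens) for cytotoxicity, with a stated time of 1 days (on this read-out higher numbers stand for lower toxicity in this test and lower numbers for higher toxicity in this test), compound 1 `CCNC(=O)c1cc(N)c(Nc2ccc(C#N)cc2)cc1Oc1c(C)cc(CCC#N)cc1C` gives 105000 nM. Compound 2 `Cc1cc(CCC#N)cc(C)c1Oc1cc(Nc2ccc(C#N)cc2)c(N)cc1CN1CCN(C)CC1` shares its core, yet for compound 2 this assay gives "not determined" (no result reported): the reading was not determined, so no single number describes where compound 2 stands, and compound 1 supplies the only measured point. Compound 3 `Cc1cc(CCC#N)cc(C)c1Oc1cc(Nc2ccc(C#N)cc2)c(N)cc1COC(=O)C1CC1` has not been measured in this assay. Compound 3 differs from compound 2 in one place, ((cyclopropylcarbonyl)oxy in place of 4-methylpiperazin-1-yl on a saturated chain carbon bound to an aromatic carbon), a change that in words is (cyclopropylcarbonyl)oxy in place of 4-methylpiperazin-1-yl on a saturated chain carbon bound to an aromatic carbon. Among the measured compounds shown here, no step between two measured compounds exists here, so the size and direction of the move from compound 2 to compound 3 in this assay cannot be read from the numbers; the only anchor is the value of compound 1, which shows low toxicity. On that basis a reading in the same region is expected, with no preferred direction beyond the scatter. The half-maximal cytotoxic concentration of compound 3 is estimated at 60000 nM, within a range from 15000 nM to 200000 nM.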

Compound 3, half-maximal cytotoxic concentration: 42200 nM
Beside the measured number, compound 3's estimate is 1.4-fold (0.15 log units) above it; the range from low to high includes it.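

In this assay this position on the shared core now has a second measured group, and the exchange of ethylcarbamoyl for ((cyclopropylcarbonyl)oxy)methyl on an aromatic carbon gives a 2.5-fold lower number from compound 1 to compound 3 (0.40 log units; beyond the scatter) on the read-out, a modest move toward higher toxicity in this test that lies beyond the scatter. The position therefore responds to the group placed on it, although compound 3 at 42200 nM still stands in the same broad region of high numbers as the earlier measured point. The change from 4-methylpiperazin-1-yl to (cyclopropylcarbonyl)oxy itself cannot be read, as compound 2 has no number, and nothing on hand explains the step from the ethylcarbamoyl compound.

The compounds shown leave open whether the cyclopropyl ring or the carbonyl-oxygen link carries this step, as no compound separates the two. They also leave open how a carboxylic acid or a plain aminomethyl group on this aromatic carbon would read in this assay and whether either would fall on the side of compound 1 or of compound 3.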